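Bromo for fluoro on the aniline ring of a salicylanilide

A few compounds are considered here, and "the series" means these few. Any claim that something is new, unique, unknown or untested is made for them only; others in the source may bear on it.

Three salicylanilides have been measured in an ADME assay on cells (Macrophage, Mus musculus) for cytotoxicity, read by resazurin assay, with a stated time of 3 days; a lower number here means a stronger inhibitor, a higher number a weaker inhibitor. Compound 1 `O=C(Nc1cc(C(F)(F)F)cc(C(F)(F)F)c1)c1cc(F)ccc1O` gives 2500 nM in this assay, and compound 2 `O=C(Nc1cc(C(F)(F)F)cc(C(F)(F)F)c1)c1cc(Br)ccc1O` gives 4900 nM. The two differ by one change, (bromo in place of fluoro on an aromatic carbon), placed meta to a large group and para to a hydroxy group, and the step is a 2.0-fold higher number from compound 1 to compound 2 (0.29 log units; within the scatter). Among the measured compounds shown here, compound 3 `O=C(Nc1cc(C(F)(F)F)ccc1F)c1cc(Cl)ccc1O` gives 2600 nM in this assay; how its core differs from that of compound 1 is not broken down here, the two numbers simply stand within the scatter of each other, as do all three values so far.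

Compound 4 `O=C(Nc1cc(C(F)(F)F)ccc1Br)c1cc(Cl)ccc1O` has not yet been measured. From compound 3 it differs by bromo in place of fluoro on an aromatic carbon, and this is the same kind of change as that from compound 1 to compound 2, though not the same: here the position is ortho to a large group and para to a trifluoromethyl group, on the aniline ring rather than the phenol ring. For the measured compounds named here, with only one earlier example of this kind of change, and that one within the scatter, the expectation for compound 4 rests on the step from compound 1 to compound 2 being a 2.0-fold higher number from compound 1 to compound 2 (0.29 log units; within the scatter). The step is therefore expected to be a 1.5-fold higher number from compound 3 to compound 4 (0.19 log units; within the scatter), small and most likely within the scatter. Compound 4 is estimated at 4000 nM in this assay, between 1500 nM and 10000 nM.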

Compound 4, half-maximal inhibitory concentration: 2900 nM
Estimate against measurement, compound 4: 1.4-fold (0.14 log units) above; the measured number falls inside the stated range.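

In this assay, bromo in place of fluoro on an aromatic carbon, here ortho to a large group and para to a trifluoromethyl group, gives a 1.1-fold higher number from compound 3 to compound 4 (0.05 log units; within the scatter). Set beside the earlier case, the exchange reads alike on both cores, with no difference between the two steps that stands clear of the scatter: the same change on two cores in this assay, a 2.0-fold higher number (0.29 log units; within the scatter) from compound 1 to compound 2 and a 1.1-fold higher number (0.05 log units; within the scatter) from compound 3 to compound 4, 1.8-fold (0.24 log units) apart, within the scatter of two such steps. Among the compounds shown here, this shows that in these two pairs the exchange stays within the scatter, at a different place on each core, but with only two pairs, neither of them beyond the scatter, it does not establish a size or direction for the change, nor show that the exchange would stay this small on other cores or at other places.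

The compounds shown carry only fluoro or bromo at the place of exchange on each pair, so it remains open whether a methyl, a methoxy or a nitrile at that aromatic carbon of compound 3 would also give a number within the scatter of compound 3. From the compounds shown here alone, it also remains open how the same exchange would read if the hydroxy group were replaced by a methoxy group or the amide by a sulfonamide.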